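Halogen swap on the phenoxy ring: compound 1 to compound 3

The compounds below may be only part of what the source reports. "The series", "measured", "known", "first", "only" and "open" are said of these compounds alone.

Compound 1 `CCSc1nnc(Cc2ccc(Cl)cc2Oc2ccccc2Cl)[nH]1` is the reference point. In a functional assay on the whole organism (strain NMRI) with Mus musculus as the target, with a stated time of 60 min, at a dose of 10 mg/kg by the intraperitoneal route (a higher number here means a stronger effect of the compound at the dose given, a lower number a weaker effect), compound 1 gives 140%, the higher of the two measured numbers; compound 2 `CCCSc1nnc(Cc2ccc(Cl)cc2Oc2ccccc2Cl)[nH]1` gives 125%, and the step is a number 15 percentage points lower from compound 1 to compound 2 (beyond the scatter). Compound 3 `CCSc1nnc(Cc2ccc(Cl)cc2Oc2ccccc2F)[nH]1` is not yet measured; it differs from compound 1 by fluoro in place of chloro on an aromatic carbon. For the measured compounds named here, the one measured step concerns the chain at the sulfur, not the halogen on the phenoxy group, so no measured step bears on this change. The expected step is therefore a number 10 percentage points lower from compound 1 to compound 3 (within the scatter), not beyond the scatter. Compound 3 is estimated at 130%, with a range from 100% to 160%.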

Compound 3, a percentage reported as activity, at one dose (the size of the read-out at that dose, not a potency): 144%
Estimate against measurement, compound 3: 14 percentage points below; measured number inside the range.
By their numbers in this assay, from the lowest: compound 2; then compounds 1 and 3 (each within the scatter of the next).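

In this assay, the change from 2-chlorophenoxy to 2-fluorophenoxy gives a number 4 percentage points higher from compound 1 to compound 3 (within the scatter), so at this dose the two halogens are not separated at this position. The chain at the sulfur does separate compounds, with a number 15 percentage points lower from compound 1 to compound 2 (beyond the scatter). No available evidence accounts for the result on the halogen swap.

Open, on these data alone, is whether a methoxy group or a trifluoromethyl group at this position, or no substituent at all, would keep the read-out. Also open, as far as these compounds go, is whether fluoro in place of chloro gives the same result on compound 2.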